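Isopentyl in Place of Acetyl: Expected Cytotoxicity of Compound 4

The source may hold more compounds than are shown below. What is called first, only, known or untested is meant among the compounds shown, and "the series" means these compounds.

Measured so far in a functional assay on A549 cells (Homo sapiens) for cytotoxicity, with a stated time of 48 h; on this read-out lower numbers stand for stronger inhibition and higher numbers for weaker inhibition:
- compound 1 `CC(=O)Oc1ccc2oc(/C=C/[S+](C)[O-])cc(=O)c2c1`: 4100 nM
- compound 2 `CC(C)COc1ccc2oc(/C=C/[S+](C)[O-])cc(=O)c2c1`: 1100 nM
- compound 3 `Cc1ccc2oc(/C=C/[S+](C)[O-])cc(=O)c2c1`: 1700 nM

Compound 1 stands highest of the three numbers in this assay. The nearest to it is compound 3, with a 2.4-fold lower number from compound 1 to compound 3 (0.38 log units; beyond the scatter). The furthest is compound 2, with a 3.7-fold lower number from compound 1 to compound 2 (0.57 log units; beyond the scatter). Between compound 2 and compound 3 the gap is a 1.5-fold higher number from compound 2 to compound 3 (0.19 log units; within the scatter).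

Compound 4 `CC(C)CCOc1ccc2oc(/C=C/[S+](C)[O-])cc(=O)c2c1` is the unmeasured member. Relative to compound 1 the change is isopentyl in place of acetyl on an oxygen on an aromatic ring. Among the measured compounds shown here, the step that bears most directly on it is the one from compound 1 to compound 2, where isobutyl also took the place of acetyl on the same oxygen and gave a 3.7-fold lower number from compound 1 to compound 2 (0.57 log units; beyond the scatter). The step from compound 1 to compound 3, with a 2.4-fold lower number from compound 1 to compound 3 (0.38 log units; beyond the scatter), points the same way. Compound 4 carries a chain one carbon longer than compound 2, and with only these three points no separate trend for chain length can be read.

Compound 4 is therefore expected to fall near compound 2, with a 4.1-fold lower number from compound 1 to compound 4 (0.61 log units; beyond the scatter). The estimate for compound 4 in this assay is 1000 nM, within a range from 400 nM to 2600 nM.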

Compound 4, half-maximal inhibitory concentration: 1000 nM
Compound 4: the middle estimate sits on the measured number at the digits printed; measured number inside the range.
By their numbers in this assay, from the lowest: compounds 4, 2 and 3 (each within the scatter of the next); then compound 1.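

In this assay, isopentyl in place of acetyl on the oxygen gives a 4.1-fold lower number from compound 1 to compound 4 (0.61 log units; beyond the scatter) as its result, so a second saturated chain at this place now stands apart from the acetoxy compound. Going from isobutyl to isopentyl gives a 1.1-fold lower number from compound 2 to compound 4 (0.04 log units; within the scatter) and thus no readable effect of the added length, while the comparison with the methyl compound gives a 1.7-fold lower number from compound 3 to compound 4 (0.23 log units; within the scatter) and likewise separates nothing, leaving compound 1 alone apart from compounds 2, 3 and 4. No measurement at hand gives a reason why the acetyl compound stands apart.

Going by these compounds, whether a longer chain such as octyl, or a chain ending in an amine or a carboxylic acid, would stay at this level remains open. So does whether another acyl group, such as benzoyl, would sit with compound 1 or with the saturated chains.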